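Swapping the benzylic amine on a shared quinoline-sulfonamide core

This account rests on a few compounds, and the source may have more. Where it says the series, first, only, none or still open, it means among the compounds named here.

The series shares one core and varies only the amine carried on a saturated chain carbon bound to an aromatic carbon. Compound 1 `CCN(CC)Cc1ccc(-c2ccnc3ccc(-c4cnc(OC)c(NS(=O)(=O)c5ccc(F)cc5F)c4)cc23)cc1` is the diethylamino member and in a functional assay on A549 cells (Homo sapiens) for cytotoxicity, read by MTT assay, with a stated time of 72 h (a higher number here means a weaker inhibitor, a lower number a stronger inhibitor), compound 1 gives 22 nM. Compound 2 `CNCCN(C)Cc1ccc(-c2ccnc3ccc(-c4cnc(OC)c(NS(=O)(=O)c5ccc(F)cc5F)c4)cc23)cc1` gives 13 nM, and compound 3 `COc1ncc(-c2ccc3nccc(-c4ccc(CN5CCCCC5)cc4)c3c2)cc1NS(=O)(=O)c1ccc(F)cc1F`, carrying piperidin-1-yl, gives 15.5 nM. Compound 3 thus stands second highest of the three numbers, with compound 2 nearest and compound 1 furthest, and every gap is within the scatter: a 1.7-fold lower number from compound 1 to compound 2 (0.23 log units; within the scatter), a 1.4-fold lower number from compound 1 to compound 3 (0.15 log units; within the scatter) and a 1.2-fold higher number from compound 2 to compound 3 (0.08 log units; within the scatter).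

Compound 4 `COc1ncc(-c2ccc3nccc(-c4ccc(CN5CCN(C(C)C)CC5)cc4)c3c2)cc1NS(=O)(=O)c1ccc(F)cc1F` continues the same theme: 4-isopropylpiperazin-1-yl in place of piperidin-1-yl on a saturated chain carbon bound to an aromatic carbon. All three measured steps at this position were within the scatter, so no change beyond the scatter is expected for the step of a 1.0-fold lower number from compound 3 to compound 4 (0.01 log units; within the scatter) in this assay. Compound 4 is therefore expected to give about 15 nM, with a range from 6 nM to 40 nM.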

Compound 4, half-maximal inhibitory concentration: 1.9 nM
Estimate against measurement, compound 4: 7.9-fold (0.90 log units) above; measured number below the stated range.
By their numbers in this assay, from the lowest: compound 4; then compounds 2, 3 and 1 (each within the scatter of the next).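

At the saturated chain carbon bound to an aromatic carbon, this assay now shows steps beyond the scatter, with an 8.2-fold lower number from compound 3 to compound 4 (0.91 log units; beyond the scatter), and 4-isopropylpiperazin-1-yl also stands apart from the other two amines, with a 6.8-fold lower number from compound 2 to compound 4 (0.84 log units; beyond the scatter) and a 12-fold lower number from compound 1 to compound 4 (1.06 log units; beyond the scatter). The position is therefore not indifferent to the amine it carries, although the three amines of compounds 1, 2 and 3 lie within the scatter of each other. Nothing available here explains why compound 4 stands apart.

The compounds shown leave open whether the step belongs to the second ring nitrogen, to the isopropyl group or to the two together. Piperazin-1-yl and 4-methylpiperazin-1-yl at the same place would begin to separate these, and morpholin-4-yl would test the ring with a different second hetero atom.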